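The source may hold more compounds than are shown below. What is called first, only, known or untested is meant among the compounds shown, and "the series" means these compounds.

Of the compounds shown here, three on the shared core have been measured so far. In an ADME assay on tissue (MIA PaCa-2 cells, Homo sapiens) for pharmacokinetics (on this read-out higher numbers stand for a longer-lived compound and lower numbers for a shorter-lived compound), compound 1 `N[C@@H](CCC(=O)OC[C@H]1O[C@@H](n2cc(F)c(=O)[nH]c2=O)C[C@@H]1OC(=O)CC[C@H](N)C(=O)O)C(=O)O` stands at 0.292 h while compound 2 `N[C@@H](CC(=O)OC[C@H]1O[C@@H](n2cc(F)c(=O)[nH]c2=O)C[C@@H]1O)C(=O)O` stands at 0.273 h and compound 3 `CC(C)[C@H](N)C(=O)OC[C@H]1O[C@@H](n2cc(F)c(=O)[nH]c2=O)C[C@@H]1O` stands at 0.188 h on this read-out. Compound 3 lies within the scatter of both other compounds, so the three cannot be ranked.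

Compound 4 `CC(C)[C@H](N)C(=O)OC[C@H]1O[C@@H](n2cc(F)c(=O)[nH]c2=O)C[C@@H]1OC(=O)[C@@H](N)C(C)C` follows from compound 3 by one change, (1-amino-2-methylpropyl)carbonyl in place of hydrogen on an oxygen on a saturated carbon in the counted difference. The hydroxy group becomes ((1-amino-2-methylpropyl)carbonyl)oxy, so a second (1-amino-2-methylpropyl)carbonyl group is present.

Among the compounds with values here, the only measured single-place step is a 1.5-fold lower number from compound 2 to compound 3 (0.16 log units; within the scatter) and it concerns the group on a carbonyl carbon, not this oxygen. Within the data shown here, no measured step isolates the new change. The nearest evidence is compound 1, which also carries an acyl group on this oxygen. Its value of 0.292 h stays within the scatter of the two compounds that keep the hydroxy group, though its groups differ from those of compound 4.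

On that basis no shift beyond the scatter is expected, and the estimated move is a 1.2-fold higher number from compound 3 to compound 4 (0.07 log units; within the scatter) in this assay as a working figure. Compound 4 is estimated at 0.22 h with an expected range of 0.11 h to 0.42 h for repeat measurements.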

Compound 4, half-life: 0.14 h
Compound 4: middle estimate off by 1.6-fold (0.20 log units), on the high side; low and high end bracket the measured number.
By their numbers in this assay, from the lowest: compounds 4, 3, 2 and 1 (each within the scatter of the next, the first and the last beyond it).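

Within the data shown here, this is the first single-place reading at this oxygen on a saturated carbon: in this assay, (1-amino-2-methylpropyl)carbonyl in place of hydrogen gives a 1.3-fold lower number from compound 3 to compound 4 (0.13 log units; within the scatter). On this read-out, the hydroxy group can therefore be replaced by ((1-amino-2-methylpropyl)carbonyl)oxy without a shift beyond the scatter, so a second (1-amino-2-methylpropyl)carbonyl group on the shared core leaves the half-life unresolved from that of the compound with one such group. Nothing measured here bears on what lies behind this step.

This single step at the position says nothing about other groups on the same oxygen, and an acetyl group, a longer unbranched acyl chain or a simple methyl ether could each give a different reading. Going by these compounds, it also remains open whether an acyl group carrying no amine would stay within the scatter of the hydroxy compound, and whether a change at this oxygen would read the same with a group other than 1-amino-2-methylpropyl on the carbonyl carbon of the first ester.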